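The source may report more compounds than this note shows. Statements on the series, on what has been measured and on what is new or still open speak of the compounds shown alone.

Measured in an assay on isolated protein for inhibition of 2-Hydroxyacid oxidase 2 (Homo sapiens), tested at 10 uM; on this read-out higher numbers stand for a stronger effect at the one concentration tested and lower numbers for a weaker effect:

Compound 1 `Cc1n[nH]c(C(=O)O)c1Cc1cccc(-c2ccc(OC(F)(F)F)cc2)c1`: 34%
Compound 2 `Cc1n[nH]c(C(=O)O)c1Cc1cccc(-c2ccc(C#N)cc2)c1`: 46%
Compound 3 `Cc1n[nH]c(C(=O)O)c1Cc1cccc(-c2ccc(C(N)=O)cc2)c1`: 60%

Compound 2 sits second highest of the three, with compound 1 lower by a number 12 percentage points higher from compound 1 to compound 2 (beyond the scatter) and compound 3 higher by a number 14 percentage points higher from compound 2 to compound 3 (beyond the scatter); the remaining step, a number 26 percentage points higher from compound 1 to compound 3 (beyond the scatter), is the largest of the three. All three steps exchange one group on the distal ring and each is modest.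

Compound 4 `Cc1n[nH]c(C(=O)O)c1Cc1cccc(C(=O)O)c1` is not yet measured. Its change from compound 2 is carboxy in place of 4-cyanophenyl on an aromatic carbon, placed on an aromatic carbon of a six-membered aromatic ring of carbon only, meta to a large group. Within the data shown here, no measured step bears directly on this change: every step so far keeps the second ring and varies only its substituent. The measured steps therefore set only the rough scale of what substituent changes do here, not what removing the whole 4-cyanophenyl does. The expectation for compound 4 in this assay is a weaker effect, a step of a number 24 percentage points lower from compound 2 to compound 4 (beyond the scatter), with wide uncertainty. Compound 4 is estimated at 22%, between 5% and 45%.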

Compound 4, a percentage reported as inhibition, at one concentration (the size of the read-out at that concentration, not a potency): 0%
Estimate against measurement, compound 4: 22 percentage points above, outside the stated range (below it).
By their numbers in this assay, from the lowest: compound 4; then compound 1; then compound 2; then compound 3.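

Exchanging 4-cyanophenyl for carboxy gives a number 46 percentage points lower from compound 2 to compound 4 (beyond the scatter) in this assay, and this large step exceeds every step seen among the substituent changes on the second ring. The position therefore tolerates exchanges of the group carried by that ring far better than this exchange of the whole 4-cyanophenyl, at least across the compounds shown. Compound 4, the only one of the four without the second ring, stands lowest at 0%, and no measurement shown gives a reason for this loss.

This single step removes the ring and brings in the carboxy together, so the contribution of each remains unresolved. Open too, on these data alone, is whether an amine or a methyl in the same place, or a phenyl ring bearing a carboxylic acid, would retain any of the effect.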